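Fluoro for Methoxy on the Benzyl Arm of Compound 2

A few compounds are considered here, and "the series" means these few. Any claim that something is new, unique, unknown or untested is made for them only; others in the source may bear on it.

Compound 2 `COc1cccc(Cn2cnc3sc(-c4ccnc(N)c4)cc3c2=O)c1` holds the lowest of the two numbers obtained in an assay on isolated protein for inhibition of Rho-associated protein kinase 1 (Homo sapiens), read by radiometric assay and 33P incorporation, with a stated time of 40 min, in the presence of a further agent that is not named here (on this read-out lower numbers stand for stronger inhibition and higher numbers for weaker inhibition), where compound 2 gives 18 nM. Its nearest neighbour, compound 1 `COc1cccc(Cn2cnc3sc(-c4ccncc4)cc3c2=O)c1`, gives 45 nM in this assay, and the step of a 2.5-fold lower number from compound 1 to compound 2 (0.40 log units; beyond the scatter) is carried by the amino in place of hydrogen on an aromatic carbon. Compound 3 `COc1cccc(Cn2cnc3sc(-c4ccc(N)nc4)cc3c2=O)c1` reaches only a limit, > 10000 nM, in this assay. That limit is the limit of > 10000 nM in this assay, at which 1 of the 3 values shown sits. From compound 1 the step of an at least 220-fold higher number from compound 1 to compound 3 (2.34 log units; beyond the scatter), and from compound 2 the step of an at least 550-fold higher number from compound 2 to compound 3 (2.74 log units; beyond the scatter), both concern the pyridyl part of the shared core.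

Compound 4 `Nc1cc(-c2cc3c(=O)n(Cc4cccc(F)c4)cnc3s2)ccn1` differs from compound 2 elsewhere: fluoro in place of methoxy on an aromatic carbon. None of the three measured steps touches that ring; all of them alter the pyridyl group, so nothing measured here tells how large a step swapping methoxy for fluoro should bring. Among the measured compounds shown here, with no direct precedent, a step within the scatter is expected, namely a 1.4-fold higher number from compound 2 to compound 4 (0.14 log units; within the scatter). Compound 4 is therefore estimated at 25 nM in this assay, with an expected range from 8 nM to 80 nM.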

Compound 4, half-maximal inhibitory concentration: 34 nM
Compound 4: the middle estimate sits 1.4-fold (0.13 log units) below what was measured; low and high end bracket the measured number.
By their numbers in this assay, from the lowest: compounds 2, 4 and 1 (each within the scatter of the next, the first and the last beyond it). At a limit, above all of these: compound 3.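

In this assay, the only step shown away from the pyridyl part, fluoro in place of methoxy on the benzyl arm, comes to a 1.9-fold higher number from compound 2 to compound 4 (0.28 log units; within the scatter), so the two groups cannot be told apart at this place on the six-membered aromatic ring, and the 3-methoxyphenyl group can give way to 3-fluorophenyl with the number staying within the scatter of compound 2. The pyridyl part of the same series behaves quite differently, with an at least 550-fold higher number from compound 2 to compound 3 (2.74 log units; beyond the scatter), a step that rests on the assay limit reached by compound 3, so the benzyl arm is so far the part of these compounds where a change has left the number within the scatter. Nothing among the measurements on hand bears on why the two groups read alike here.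

Going by these compounds, the benzyl arm is represented only by methoxy and fluoro, so it remains open how this place would respond to a larger or differently built group such as a chloro, an amine, a carboxylic acid or a longer chain like butoxy. On these data alone, it is also open whether fluoro would read the same way on the pyridin-4-yl group of compound 1.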